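Fluorophenyl swaps in the series: compound 2 to compound 3

The compounds below may be only part of what the source reports. "The series", "measured", "known", "first", "only" and "open" are said of these compounds alone.

Measured in an ADME assay on microsomes from liver (Homo sapiens) for metabolic stability, read by LC-MS; a lower number here means that the compound disappears faster, a higher number that the compound lasts longer:
- compound 1 `O=C(Nc1ccc(F)c(-c2nc3ncc(-c4ccc(F)c(F)c4)cc3[nH]2)c1)N1CCCC1`: 0.282 h
- compound 2 `O=C(Nc1ccc(F)c(-c2nc3ncc(-c4cc(F)cc(F)c4)cc3[nH]2)c1)N1CCCC1`: 0.175 h

Among the measured compounds shown here, compound 2 stands level with the only other measured compound. For the measured compounds named here, the one step available is a 1.6-fold lower number from compound 1 to compound 2 (0.21 log units; within the scatter).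

The next change leads to compound 3 `O=C(Nc1ccc(F)c(-c2nc3ncc(-c4ccccc4F)cc3[nH]2)c1)N1CCCC1`: 2-fluorophenyl in place of 3,5-difluorophenyl on an aromatic carbon. This puts 2-fluorophenyl in place of 3,5-difluorophenyl on an aromatic carbon. Going by the values given here, the measured step also exchanged one fluorinated phenyl group for another at this place, but no measured step shows the loss of a fluorine. No step beyond the scatter is therefore expected in this assay, in either direction. The expected step is a 1.3-fold higher number from compound 2 to compound 3 (0.10 log units; within the scatter). For compound 3 the estimated half-life is 0.22 h, with an expected range of 0.11 h to 0.45 h.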

Compound 3, half-life: 0.285 h
Estimate against measurement, compound 3: 1.3-fold (0.11 log units) below; measured number inside the range.
By their numbers in this assay, from the lowest: compounds 2, 1 and 3 (each within the scatter of the next).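

In this assay the loss of a fluorine at this position can now be read, as 2-fluorophenyl replaces 3,5-difluorophenyl (a 1.6-fold higher number from compound 2 to compound 3 (0.21 log units; within the scatter)) and 3,4-difluorophenyl (a 1.0-fold higher number from compound 1 to compound 3 (0.00 log units; within the scatter)). All three fluorinated phenyl groups on this aromatic carbon therefore stand within the scatter of one another. No evidence on hand bears on this result.

Still open, from the compounds shown here alone, is whether a group other than fluorinated phenyl at this place, such as an amine or a carboxylic acid, would give a step beyond the scatter. Going by these compounds, the effect of the unsubstituted phenyl group also remains open.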